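A few compounds are considered here, and "the series" means these few. Any claim that something is new, unique, unknown or untested is made for them only; others in the source may bear on it.

Compound 1, `Cc1ccnc(/C(N)=N/NC(=S)N2CCSCC2)c1`: in a functional assay on A-375 cells (Homo sapiens) for cytotoxicity, read by MTT assay, with a stated time of 72 h (on this read-out lower numbers stand for stronger inhibition and higher numbers for weaker inhibition), compound 1 gives 1200 nM.
Compound 2, `Cc1ccnc(/C(N)=N/NC(=S)N2CCCC2)c1`: in this assay compound 2 gives 720 nM.
Compound 3, `Cc1ccnc(/C(N)=N/NC(=S)N2CCCCCC2)c1`: in this assay compound 3 gives 800 nM.

Among these three, compound 2 carries the smallest number, but its gaps to compound 3 and to compound 1 both lie within the scatter, so the three cannot be separated on this read-out. The step to compound 4, `Cc1ccnc(/C(N)=N/NC(=S)N2CCCCC2)c1`, changes the ring on the thiocarbonyl carbon: piperidin-1-yl in place of pyrrolidin-1-yl on a thiocarbonyl carbon. Among the compounds with values here, the one measured step at that same place, a 1.7-fold lower number from compound 1 to compound 2 (0.22 log units; within the scatter), stayed within the scatter, and the pair of compound 2 and compound 3, with no step computed for it, likewise shows two numbers that sit close together. Swapping one saturated ring for another of neighbouring size at this position has therefore not yet produced a step beyond the scatter in this assay, and none is expected here. Compound 4 is estimated at 760 nM, with a range of 400 nM to 1450 nM. The expected step is a 1.1-fold higher number from compound 2 to compound 4 (0.02 log units; within the scatter), a change within the scatter.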

Compound 4, half-maximal inhibitory concentration: 1900 nM
The estimate for compound 4 lay 2.5-fold (0.40 log units) below the measured number; measured number above the stated range.
By their numbers in this assay, from the lowest: compounds 2, 3, 1 and 4 (each within the scatter of the next, the first and the last beyond it).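

In this assay, within the data shown here, the group on the thiocarbonyl carbon can move the number beyond the scatter: piperidin-1-yl in place of pyrrolidin-1-yl gives a 2.6-fold higher number from compound 2 to compound 4 (0.42 log units; beyond the scatter), the first step at this place to pass the scatter, though only a modest one. The same piperidin-1-yl in place of thiomorpholin-4-yl gives a 1.6-fold higher number from compound 1 to compound 4 (0.20 log units; within the scatter), so compound 4 is not separated from compound 1. Exchanging one saturated ring for another at this place is therefore not always silent, yet the effect depends on the pair compared, and only compound 2 and compound 4 stand apart.

From the compounds shown here alone, whether morpholin-4-yl or an open-chain diethylamino group on the thiocarbonyl carbon would stay close to compound 2 or to compound 4 remains open. Nothing given here accounts for the step from the five-membered to the six-membered ring.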